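Trifluoromethyl in place of methoxy on the pyridone ring

The source may hold more compounds than are shown below. What is called first, only, known or untested is meant among the compounds shown, and "the series" means these compounds.

Among the three compounds measured in an assay on isolated protein for inhibition of histone-lysine N-methyltransferase EZH2 (Homo sapiens), read by filter binding, with a stated time of 1 h (on this read-out higher numbers stand for weaker inhibition and lower numbers for stronger inhibition), compound 2 `COc1cc(C)n(C)c(=O)c1CN1CCc2c(Cl)cc(-c3c(C)noc3C)c(Cl)c2C1=O` stands lowest, with 11.6 nM. Compound 1 `CCc1cc(C)n(C)c(=O)c1CN1CCc2c(Cl)cc(-c3c(C)noc3C)c(Cl)c2C1=O` gives 82 nM and compound 3 `Cc1noc(C)c1-c1cc(Cl)c2c(c1Cl)C(=O)N(Cc1c(C3CC3)cc(C)n(C)c1=O)CC2` gives 302 nM. Compound 4 `Cc1noc(C)c1-c1cc(Cl)c2c(c1Cl)C(=O)N(Cc1c(C(F)(F)F)cc(C)n(C)c1=O)CC2` differs from compound 2 by trifluoromethyl in place of methoxy on an aromatic carbon. Going by the values given here, no trifluoromethyl analogue has been measured, so the nearest guides are the two steps away from methoxy: a 26-fold higher number from compound 2 to compound 3 (1.42 log units; beyond the scatter), and the reverse of a 7.1-fold lower number from compound 1 to compound 2 (0.85 log units; beyond the scatter). Both replacements of methoxy by a group without a hydrogen-bond acceptor raised the number beyond the scatter, so a higher number is expected for compound 4 as well, of modest size, an 8.6-fold higher number from compound 2 to compound 4 (0.94 log units; beyond the scatter). The estimate for compound 4 in this assay is therefore 100 nM, with a range from 30 nM to 350 nM.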

Compound 4, half-maximal inhibitory concentration: > 1000 nM
Compound 4 ended at the assay's limit; the forecaster's own chance of this, stated with the estimate: 2%; middle value at least 10-fold (1.00 log units) away from the limit.
By their numbers in this assay, from the lowest: compound 2; then compound 1; then compound 3. At a limit, above all of these: compound 4.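

In this assay compound 4 gives > 1000 nM, which is a limit of the assay and not a number. Trifluoromethyl thus sits beyond every other group tried at this position, with an at least 86-fold higher number from compound 2 to compound 4 (1.93 log units; beyond the scatter), an at least 12-fold higher number from compound 1 to compound 4 (1.08 log units; beyond the scatter) and an at least 3.3-fold higher number from compound 3 to compound 4 (0.51 log units; beyond the scatter). The three groups without the oxygen of methoxy also differ clearly among themselves, so losing that oxygen does not alone set the number.

As far as these compounds go, how far compound 4 lies past its limit stays open. So does whether an ethoxy group or an amine at this position would match methoxy.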